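Cyclohexyl in place of carboxymethyl on an amine nitrogen

This account rests on a few compounds, and the source may have more. Where it says the series, first, only, none or still open, it means among the compounds named here.

Measured in a functional assay on MCF7 cells (Homo sapiens) for antiproliferative activity; a lower number here means a stronger inhibitor, a higher number a weaker inhibitor:
Compound 1 `CC(C)=CCc1cc(C(=O)Nc2cc3ccc(OCCCN(C(C)C)C(C)C)c(C)c3oc2=O)ccc1O`: 1310 nM
Compound 2 `CC(C)=CCc1cc(C(=O)Nc2cc3ccc(OCCCNCC(=O)O)c(C)c3oc2=O)ccc1O`: 18100 nM

Compound 2 holds the higher number of the two, at 18100 nM. Compound 3 `CC(C)=CCc1cc(C(=O)Nc2cc3ccc(OCCCNC4CCCCC4)c(C)c3oc2=O)ccc1O` carries cyclohexyl in place of carboxymethyl on an amine nitrogen. For the measured compounds named here, the only measured step bearing on this is large and beyond the scatter: a 14-fold higher number from compound 1 to compound 2 (1.14 log units; beyond the scatter). Compound 3, like compound 1, lacks the carboxymethyl, so a large step to a lower number is expected in this assay, close to the reverse of that step. Going by the values given here, no measured compound carries cyclohexyl, so the range stays wide. The expected step is a 10-fold lower number from compound 2 to compound 3 (1.00 log units; beyond the scatter). Compound 3 is estimated at 1800 nM, with an expected range of 600 nM to 6000 nM.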

Compound 3, half-maximal inhibitory concentration: 1070 nM
Beside the measured number, compound 3's estimate is 1.7-fold (0.23 log units) above it; the range from low to high includes it.
By their numbers in this assay, from the lowest: compounds 3 and 1 (each within the scatter of the next); then compound 2.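

In this assay, cyclohexyl in place of carboxymethyl on an amine nitrogen gives a 17-fold lower number from compound 2 to compound 3 (1.23 log units; beyond the scatter). Cyclohexylamino in place of diisopropylamino gives a 1.2-fold lower number from compound 1 to compound 3 (0.09 log units; within the scatter), so these two amine groups are not told apart here, and among the three compounds only the carboxymethyl compound stands apart. Nothing available explains this difference.

Open, on these data alone, is whether the methyl ester of the carboxylic acid stays with compound 2 or moves towards compound 1 and compound 3. Also open, as far as these compounds go, is how an unsubstituted amine, a morpholine ring or a longer chain would compare.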